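The source may hold more compounds than are shown below. What is called first, only, known or untested is meant among the compounds shown, and "the series" means these compounds.

Measured compounds:
compound 1 `CCN1CCN(c2cc(C)c3cc(NC(=O)c4ccccc4)ccc3n2)CC1`: 14200 nM
compound 2 `CCN(CC)c1cc(C)c2cc(NC(=O)c3ccc(Cl)c(Cl)c3)ccc2n1`: > 50000 nM

Among the measured compounds shown here, in a functional assay on MCF7 cells (Homo sapiens) for antiproliferative activity, read by MTT assay, with a stated time of 72 h (a lower number here means a stronger inhibitor, a higher number a weaker inhibitor), compound 1 gives 14200 nM, the only plain number among the two values shown. Compound 2 gives only > 50000 nM, which is a limit of this assay rather than a number (the limit of > 50000 nM in this assay, at which 1 of the 2 values shown sits). Compound 3 `CCN1CCN(c2cc(C)c3cc(NC(=O)c4ccc(Cl)cc4)ccc3n2)CC1` is not yet measured; it differs from compound 1 by chloro in place of hydrogen on an aromatic carbon. For the measured compounds named here, no measured pair isolates this change, so its step size is unknown, and compound 2 differs in more places than this one. A change no larger than the usual scatter, in either direction, is expected. Compound 3 is therefore expected at 15000 nM, between 5000 nM and 45000 nM, an expected step of a 1.1-fold higher number from compound 1 to compound 3 (0.02 log units; within the scatter).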

Compound 3, half-maximal inhibitory concentration: 1530 nM
The estimate for compound 3 lay 9.8-fold (0.99 log units) above the measured number, and the stated range ends above it.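

In this assay chloro in place of hydrogen on this aromatic carbon, para to a large group, brings a 9.3-fold lower number from compound 1 to compound 3 (0.97 log units; beyond the scatter) and so shows that this position is not indifferent: one added chlorine atom moves the number beyond the usual scatter. Nothing shown explains why this change has so large an effect.

The compounds shown leave open whether the gain is specific to chloro or would also appear with fluoro, methoxy or an amine at this position. They also leave open how a longer chain would fare there.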